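Aryl swap from compound 3 to compound 4

The compounds below may be only part of what the source reports. "The series", "measured", "known", "first", "only" and "open" are said of these compounds alone.

Of the compounds shown here, three have numbers so far in an ADME assay on CHO cells (Cricetulus griseus) for cytotoxicity, read by MTT assay; a lower number here means that less compound is tolerated, a higher number that more compound is tolerated. Compound 1 (`Fc1ccc(Nc2cc3[nH]c(Nc4ccc(N5CCN(CC6CC6)CC5)cn4)nc3cn2)cc1C(F)(F)F`) gives 41000 nM, compound 2 (`C[C@@H]1CN(c2ccc(Nc3nc4cnc(Nc5ccc(F)c(F)c5)cc4[nH]3)nc2)C[C@H](C)N1`) gives 2700 nM, and compound 3 (`C[C@@H]1CN(C(=O)c2ccnc(Nc3nc4cnc(Nc5cccc(C(F)(F)F)c5)cc4[nH]3)c2)C[C@H](C)N1`) gives 37000 nM. Compound 3 stands level with compound 1 within the scatter and lies well above compound 2, a gap beyond the scatter.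

Compound 4 (`C[C@@H]1CN(C(=O)c2ccnc(Nc3nc4cnc(Nc5ccc(F)c(F)c5)cc4[nH]3)c2)C[C@H](C)N1`) keeps the rest of compound 3 but carries 3,4-difluorophenyl in place of 3-(trifluoromethyl)phenyl on a nitrogen on an aromatic ring. Going by the values given here, no measured pair isolates this change. Among the compounds with values here, the only guide is compound 2, which carries the same 3,4-difluorophenyl and gives 2700 nM, but it also differs from compound 3 elsewhere, so its number cannot be carried over directly. A moderate downward step in this assay is therefore expected, probably just beyond the scatter and stopping short of the level of compound 2. The estimate amounts to a 2.6-fold lower number from compound 3 to compound 4 (0.42 log units; beyond the scatter). Compound 4 is expected at 14000 nM, with an estimated range of 4000 nM to 40000 nM.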

Compound 4, half-maximal cytotoxic concentration in the CHO assay: > 50000 nM
Compound 4: a limit, no number; the forecaster's own chance of this, stated with the estimate: 3%; at least 3.5-fold (0.55 log units) between middle value and limit.
By their numbers in the CHO assay, from the lowest: compound 2; then compounds 3 and 1 (each within the scatter of the next). At a limit, above all of these: compound 4.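

In the CHO assay compound 4 gives > 50000 nM as a limit of the assay and not a number. In the CHO assay 3,4-difluorophenyl in place of 3-(trifluoromethyl)phenyl on a nitrogen on an aromatic ring gives an at least 1.3-fold higher number from compound 3 to compound 4 (0.13 log units; that floor lies within the scatter) so this pair shows no drop on losing the trifluoromethyl group, and the size of the step stays unknown because one side of it is a limit: the limit of > 50000 nM in the CHO assay, at which 1 of the 4 values shown sits.

In a physicochemical assay for solubility, read by HPLC, using the shake flask method, in phosphate buffer, measured as kinetic solubility, with a stated time of 20 h, at pH 6.5 (a higher number here means a more soluble compound, a lower number a less soluble compound), compound 3 gives 200000 nM and compound 4 gives 100000 nM and the same swap gives a 2.0-fold lower number from compound 3 to compound 4 (0.30 log units; within the scatter) so this pair offers no readable solubility difference between the two aryl groups and the change carries no visible cost there.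

Still open is whether an unsubstituted phenyl, a methoxyphenyl or a pyridine ring on this nitrogen would hold the same level in the CHO assay and in the physicochemical assay since both aryl groups shown in this pair carry fluorine. Also open, on these data alone, are how far compound 4 really lies from its limit and whether the swap reads the same way when the rest of the molecule differs from that of compound 3.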